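A few compounds are considered here, and "the series" means these few. Any claim that something is new, unique, unknown or untested is made for them only; others in the source may bear on it.

Compound 1 `COc1cc(-c2nn(-c3cccc(NC(=O)c4ccc(Cl)c(C(F)(F)F)c4)c3)cc2-c2ccncc2)ccc1Cl`, compound 2 `O=C(Nc1cccc(-n2cc(-c3ccncc3)c(-c3ccc(Cl)c(O)c3)n2)c1)Nc1cc(C(F)(F)F)cc(C(F)(F)F)c1` and compound 3 `COc1cc(-c2nn(-c3cccc(NC(=O)Nc4ccc(Cl)c(C(F)(F)F)c4)c3)cc2-c2ccncc2)ccc1Cl` were measured in a functional assay on 786-0 cells (Homo sapiens) for inhibition, read by sulforhodamine B assay, with a stated time of 48 h; a higher number here means a weaker inhibitor of growth, a lower number a stronger inhibitor of growth. Compound 1 gives > 32500 nM, which is a limit of the assay rather than a number. Compound 2 gives 3160 nM and compound 3 gives 8020 nM.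

Compound 2 thus holds the lowest of the two numbers, with compound 3 nearest, a gap beyond the scatter. Among the compounds with values here, the one measured step, an at least 4.0-fold lower number from compound 1 to compound 3 (0.60 log units; beyond the scatter), changes the linker on a carbonyl carbon and says nothing directly about trimming a trifluoromethyl group. Compound 4 `O=C(Nc1cccc(-n2cc(-c3ccncc3)c(-c3ccc(Cl)c(O)c3)n2)c1)Nc1cccc(C(F)(F)F)c1` differs from compound 2 by hydrogen in place of trifluoromethyl on an aromatic carbon. Within the data shown here, with no measured step bearing on this change, compound 2 is taken as the anchor and compound 4 is expected to give a number near it, 5000 nM, between 2000 nM and 15000 nM, a step of a 1.6-fold higher number from compound 2 to compound 4 (0.20 log units; within the scatter) that may not pass the scatter.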

Compound 4, concentration for total growth inhibition: > 32500 nM
Compound 4: a limit, no number (the forecaster's own chance of this, stated with the estimate: 10%); middle value at least 6.5-fold (0.81 log units) from the limit.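

In this assay, within the data shown here, this aromatic carbon proves far from indifferent: hydrogen in place of trifluoromethyl gives an at least 10-fold higher number from compound 2 to compound 4 (1.01 log units; beyond the scatter), the first measured step at this position. Compound 4 gives a limit and not a number, so the step is only a bound: the limit of > 32500 nM in this assay, at which 2 of the 4 values shown sit.

The compounds shown do not tell whether a chlorine atom or a methyl group on this carbon would keep the number of compound 2. They also leave open whether the same change would have a similar effect on a compound carrying a methoxy group in place of the hydroxyl group of compound 2.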